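Swapping the aryl group on a triazole amide in lung cancer cells

This account rests on a few compounds, and the source may have more. Where it says the series, first, only, none or still open, it means among the compounds named here.

Measured compounds:
Compound 1, `COc1cc2c(Oc3ccc(NC(=O)c4cn(-c5ccc(Br)cc5)nn4)cc3F)ccnc2cc1OCCCN1CCCC1`: 200 nM
Compound 2, `COc1cc2c(Oc3ccc(NC(=O)c4cn(-c5ccccc5C)nn4)cc3F)ccnc2cc1OCCCN1CCCCC1`: 2100 nM

Both compounds were tested in a functional assay on NCI-H460 cells (Homo sapiens) for cytotoxicity, read by MTT assay, with a stated time of 72 h; on this read-out lower numbers stand for stronger inhibition and higher numbers for weaker inhibition. Compound 2 has the higher of the two numbers; compound 1 sits lower, and the gap between them is well beyond the scatter of repeat runs. Compound 3, `COc1cc2c(Oc3ccc(NC(=O)c4cn(-c5ccc(Br)cc5)nn4)cc3F)ccnc2cc1OCCCN1CCCCC1`, has not yet been measured. It arises from compound 2 by one change: 4-bromophenyl in place of 2-methylphenyl on an aromatic nitrogen. The new group is the same 4-bromophenyl that compound 1 carries; in the rest of the molecule compound 3 matches compound 2.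

Among the measured compounds shown here, no pair of measured compounds differs in this one place only, so the size of the step has to be estimated. Since compound 3 pairs the aryl group of compound 1, which gave 200 nM, with the remaining framework of compound 2, the expected step from compound 2 to compound 3 is a move toward stronger inhibition, estimated at a 6.0-fold lower number from compound 2 to compound 3 (0.78 log units; beyond the scatter). Compound 3 is therefore expected to give about 350 nM in this assay, within a range from 120 nM to 1200 nM.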

Compound 3, half-maximal inhibitory concentration: 360 nM
Beside the measured number, compound 3's estimate is 1.0-fold (0.01 log units) below it; the measured number falls inside the stated range.
By their numbers in this assay, from the lowest: compounds 1 and 3 (each within the scatter of the next); then compound 2.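

In this assay, the aryl group on an aromatic nitrogen of the five-membered aromatic ring now has a direct comparison: with the piperidin-1-yl end held fixed, 4-bromophenyl in place of 2-methylphenyl gives a 5.8-fold lower number from compound 2 to compound 3 (0.77 log units; beyond the scatter), so the activity in these cells responds to the choice of aryl group at this position. The other end of the molecule gets its first direct comparison too: with the 4-bromophenyl group held fixed, piperidin-1-yl in place of pyrrolidin-1-yl gives a 1.8-fold higher number from compound 1 to compound 3 (0.26 log units; within the scatter), so this ring swap shows no readable effect in this pair. Nothing at hand explains why the aryl swap shifts the number.

The aryl swap changes both the substituent and where it sits on the ring, and the compounds shown do not separate the two; a 4-methylphenyl or a 2-bromophenyl group on the same nitrogen would. Also open, on these data alone, is how a plain phenyl or a cyclohexyl group would fare at this position, and whether a morpholine at the far end of the chain would fit the same picture.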